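The source may hold more compounds than are shown below. What is called first, only, known or untested is meant among the compounds shown, and "the series" means these compounds.

Measured so far:
- compound 1 `Cc1n[nH]c2ccc(-c3nc4cnc(N5CCN(C)CC5)cn4c3Nc3ccccc3F)cc12`: "not determined" (no result reported)
- compound 2 `Cc1n[nH]c2ccc(-c3nc4cnc(N5CCN(C)CC5)cn4c3Nc3cccc(Cl)c3)cc12`: "not determined" (no result reported)
- compound 3 `Cc1n[nH]c2ccc(-c3nc4cnc(N5CCN(C)CC5)cn4c3Nc3ccc(Cl)cc3F)cc12`: 10400 nM

Three compounds of the series share one core and differ only in the aryl group on the amino nitrogen. In a functional assay on MV4-11 cells (Homo sapiens) for inhibition, with a stated time of 120 h (on this read-out lower numbers stand for stronger inhibition and higher numbers for weaker inhibition), compound 3 gives 10400 nM. Going by the values given here, compound 1 and compound 2 carry no result in this assay, so compound 3 holds the only number in the set and nothing can be said about how it stands relative to the other two. On its own, the value of compound 3 is a weak one.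

Compound 4 `Cc1n[nH]c2ccc(-c3nc4cnc(N5CCN(C)CC5)cn4c3Nc3ccc(F)c(Cl)c3)cc12` is the next entry. The change from compound 3 reads: 3-chloro-4-fluorophenyl in place of 4-chloro-2-fluorophenyl on a nitrogen on an aromatic ring. The two compounds thus hold the same atoms, with the chlorine and the fluorine swapped to other positions of the ring on the nitrogen.

Among the compounds with values here, no step between two measured compounds is available, so the size of this move cannot be read from the series itself. For a rearrangement of two halogens on a weak starting point, the expectation is a step of no more than the usual scatter, with no direction favoured. Compound 4 is therefore expected to give about 9000 nM in this assay, in a range from 3000 nM to 27000 nM, which means an expected step of a 1.2-fold lower number from compound 3 to compound 4 (0.06 log units; within the scatter).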

Compound 4, half-maximal inhibitory concentration: 2850 nM
Beside the measured number, compound 4's estimate is 3.2-fold (0.50 log units) above it; measured number below the stated range.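

In this assay, going by these compounds alone, the aryl group on the amino nitrogen proves sensitive to the arrangement of its halogens: with the same atoms present, 3-chloro-4-fluorophenyl in place of 4-chloro-2-fluorophenyl gives a 3.6-fold lower number from compound 3 to compound 4 (0.56 log units; beyond the scatter) and is the first readable step. The step is modest, and compound 4 at 2850 nM is still a weak value, so the rearrangement improves on the weak starting point without changing that overall picture. Nothing available here bears on why the number moves in this direction.

Steps involving compound 1 and compound 2 cannot be read, so it remains open whether the chlorine or the fluorine accounts for the step, as both move together between compound 3 and compound 4. Also open, going by these compounds, is how the same place on the nitrogen would respond to a ring carrying something other than halogens, such as a methoxy group, a nitrile or a carboxylic acid.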